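This account rests on a few compounds, and the source may have more. Where it says the series, first, only, none or still open, it means among the compounds named here.

In a functional assay on HL-60 cells (Homo sapiens) for cytotoxicity, read by MTT assay, with a stated time of 72 h (on this read-out higher numbers stand for weaker inhibition and lower numbers for stronger inhibition), three compounds have been measured so far. Compound 1 `COc1ccc(C(=O)OCC2=CC[C@@]3(C)CCC(C(C)C)=C3CC2)cc1` gives 30700 nM. Compound 2 `CC1=CC[C@]2(C)[C@@H]([C@@H](OC(=O)c3ccc(O)cc3)C1)[C@](O)(C(C)C)C[C@@H]2O` gives 3500 nM. Compound 3 `C/C=C(/C)C(=O)O[C@H]1CC(C)=C[C@@H](OC(=O)/C(C)=C\C)[C@@]2(C)CC[C@@](O)(C(C)C)[C@H]12` gives 2600 nM. Among these three numbers, compound 2 stands second highest: its nearest neighbour is compound 3, whose number lies within the usual scatter of repeated measurements, so nothing separates the two; its furthest neighbour is compound 1, whose number lies well beyond that scatter, so compound 1 is clearly the weaker inhibitor of the pair.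

Compound 4 `CC1=CC[C@@]2(C)CC[C@@](O)(C(C)C)[C@@H]2[C@@H](OC(=O)c2ccc(O)cc2)C1` has not yet been measured in this assay. It differs from compound 2 in one place: hydrogen in place of hydroxy on a saturated ring carbon. The change sits on a saturated ring carbon of a five-membered non-aromatic ring of carbon only, part of a fused system of two rings. Within the data shown here, no measured pair in this set shows what removing a hydroxy from such a ring carbon does to this read-out, so the expected step is uncertain. The step from compound 2 to compound 4 is expected to be small, no change at the digits printed from compound 2 to compound 4 (within the scatter), likely within the scatter. Compound 4 is therefore estimated at 3500 nM, in a range from 1400 nM to 9000 nM.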

Compound 4, half-maximal inhibitory concentration: > 100000 nM
Compound 4 was reported as a limit (the forecaster's own chance of this, stated with the estimate: 5%); middle value at least 28-fold (1.45 log units) away from the limit.
By their numbers in this assay, from the lowest: compounds 3 and 2 (each within the scatter of the next); then compound 1. At a limit, above all of these: compound 4.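

In this assay the hydroxy on this saturated ring carbon of the five-membered ring proves to matter a great deal: swapping that one group for hydrogen, with the rest of the molecule unchanged, gives an at least 28-fold higher number from compound 2 to compound 4 (1.45 log units; beyond the scatter). The value of compound 4 is a limit and not a number: the limit of > 100000 nM in this assay, at which 1 of the 4 values shown sits. Among these compounds, the earlier compounds offered no pair differing in one place, so this is the first direct sign that a single hydroxy at this position can separate a measurable cytotoxic effect from none within the range of the read-out.

On these data alone, what a methoxy group, an amine or a fluorine atom on this ring carbon would do remains open. Also open, as far as these compounds go, is whether removing this hydroxy would give so large a step with a different ester on the shared core.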